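The compounds below may be only part of what the source reports. "The series", "measured", "known", "first", "only" and "open" are said of these compounds alone.

Measured compounds in an assay on LM cells for displacement of a labelled ligand from Neuropeptide Y receptor type 5 (Homo sapiens); a higher number here means a weaker inhibitor, a lower number a stronger inhibitor:
compound 1 `Fc1ccc(C2(c3ccc(F)cc3)CNC(c3ccccc3)=N2)cc1` gives 32 nM;
compound 2 `Fc1ccc(C2(c3ccc(F)cc3)CNC(c3cccc(F)c3)=N2)cc1` gives 10 nM.

Within the data shown here, compound 2 stands lowest of the two numbers, and the single step that separates them, a 3.2-fold lower number from compound 1 to compound 2 (0.51 log units; beyond the scatter), lies beyond the scatter. Compound 3 `O=[N+]([O-])c1cccc(C2=NC(c3ccc(F)cc3)(c3ccc(F)cc3)CN2)c1` differs from compound 2 by nitro in place of fluoro on an aromatic carbon. Among the measured compounds shown here, the only measured step concerns fluoro in place of hydrogen and does not directly speak to nitro in place of fluoro; no measured compound carries a nitro group. Compound 3 is therefore expected to show no step beyond the scatter in this assay, a 1.2-fold higher number from compound 2 to compound 3 (0.08 log units; within the scatter). The estimate for compound 3 is 12 nM, between 4 nM and 40 nM.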

Compound 3, half-maximal inhibitory concentration: 4.3 nM
Compound 3: middle estimate off by 2.8-fold (0.45 log units), on the high side; the range from low to high includes it.
By their numbers in this assay, from the lowest: compound 3; then compound 2; then compound 1.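

In this assay nitro, with 3 heavy atoms, replaces fluoro at this aromatic carbon and the number still falls (a 2.3-fold lower number from compound 2 to compound 3 (0.37 log units; beyond the scatter)). Set against hydrogen at the same carbon, nitro gives a larger drop (a 7.4-fold lower number from compound 1 to compound 3 (0.87 log units; beyond the scatter)), so both groups shown here lower the number, with nitro going further than fluoro. Nothing available explains why this change lowers the number. From the compounds shown here alone, whether an amine, a nitrile or a methoxy group at this carbon would also lower the number remains open. So does whether nitro would do the same on another carbon of this ring.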